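This account rests on a few compounds, and the source may have more. Where it says the series, first, only, none or still open, it means among the compounds named here.

Measured in a functional assay on HCT-116 cells (Homo sapiens), read by MTT assay, with a stated time of 72 h; on this read-out higher numbers stand for weaker inhibition and lower numbers for stronger inhibition:
- compound 1 `C#Cc1cn([C@@H]2O[C@H](CO)[C@@H](O)[C@H]2O)c2ncnc(OC)c12`: 4060 nM
- compound 2 `CSc1ncnc2c1c(-c1cccs1)cn2[C@@H]1O[C@H](CO)[C@@H](O)[C@H]1O`: > 20000 nM (a limit of the assay, not a number)
- compound 3 `CNc1ncnc2c1c(-c1ccco1)cn2[C@@H]1O[C@H](CO)[C@@H](O)[C@H]1O`: 230 nM

Within the data shown here, only three compounds have been measured so far, and they differ from one another in more than one place. Compound 3 gives 230 nM, the lowest number in the set. The gap between it and compound 1, at 4060 nM, lies beyond the scatter. Compound 2 gives > 20000 nM, which is a limit and so cannot be placed exactly on the same scale.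

The next compound, compound 4 `CNc1ncnc2c1c(-c1ccccc1)cn2[C@@H]1O[C@H](CO)[C@@H](O)[C@H]1O`, keeps all of compound 3 except for one group: it has phenyl in place of furan-2-yl on an aromatic carbon. Among the measured compounds shown here, no measured pair differs at this carbon alone, so the size of the step has to be judged with little support. Compound 3 already sits at the low end with 230 nM, so a swap is more likely to raise the number than to lower it further. The expected result is an 8.7-fold higher number from compound 3 to compound 4 (0.94 log units; beyond the scatter), a move toward weaker inhibition and probably beyond the scatter, though this is uncertain. For compound 4 the estimated value is 2000 nM, with an expected range of 300 nM to 15000 nM.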

Compound 4, half-maximal inhibitory concentration: > 20000 nM
Compound 4: a limit, no number (the forecaster's own chance of this, stated with the estimate: 20%); middle value at least 10-fold (1.00 log units) away from the limit.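

Among these compounds, compound 3 and compound 4 form the first pair here that differs in one place only, so the effect of the group on this aromatic carbon can now be read directly. In this assay the change from furan-2-yl to phenyl gives an at least 86-fold higher number from compound 3 to compound 4 (1.93 log units; beyond the scatter) even though both groups are single aromatic rings with no net charge, so activity in this series can depend strongly on which ring sits at this carbon. The value of compound 4 is a limit and not a number, and the same limit appears elsewhere in the set: the limit of > 20000 nM in this assay, at which 2 of the 4 values shown sit.

This one pair cannot separate the two things that change together, the ring size and the ring oxygen of furan-2-yl, which counts as a hydrogen-bond acceptor where phenyl has none. It also leaves open what other groups on this carbon would give with the rest of compound 3 kept, such as a pyridin-2-yl ring, which is six-membered but carries a ring nitrogen, or a plain methyl group with no ring at all.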